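This account rests on a few compounds, and the source may have more. Where it says the series, first, only, none or still open, it means among the compounds named here.

Working notes on the series. In an assay on isolated protein for inhibition of Rho-associated protein kinase 1 (Homo sapiens), tested at 30 uM (on this read-out lower numbers stand for less inhibition and higher numbers for more inhibition at the one concentration tested (going by the name of the read-out)), compound 1 `Fc1ccc(Sc2ncnc3[nH]cnc23)cc1` gives 37% and compound 2 `Clc1ncnc2ncn(Cc3ccccc3)c12` gives 6%, so compound 2 stands lowest of the two numbers, its nearest neighbour being compound 1, whose number is higher by a margin beyond the usual scatter. Compound 3 `Fc1ccc(Cn2cnc3ncnc(Cl)c32)cc1` is not yet measured. It differs from compound 2 by fluoro in place of hydrogen on an aromatic carbon. Among the compounds with values here, no measured pair shows this change, so a small step is expected, within the scatter, in either direction. The expected step in this assay is a number 3 percentage points higher from compound 2 to compound 3 (within the scatter). Compound 3 is estimated at 9%, with a range from 0% to 25%.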

Compound 3, a percentage reported as inhibition, at one concentration (the size of the read-out at that concentration, not a potency): 7%
Estimate against measurement, compound 3: 2 percentage points above, within the range that was stated.
By their numbers in this assay, from the lowest: compounds 2 and 3 (each within the scatter of the next); then compound 1.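

In this assay, within the data shown here, fluoro in place of hydrogen on an aromatic carbon, para to a large group, gives a number 1 percentage points higher from compound 2 to compound 3 (within the scatter) as the first measured step for this change. At this place, compound 2 and compound 3 cannot be told apart on this read-out. No supporting data bear on this result.

As far as these compounds go, whether an amine or a carboxylic acid at the same place would give a step beyond the scatter remains open. So does whether fluoro would behave the same way at another carbon of that ring.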